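The source may report more compounds than this note shows. Statements on the series, on what has been measured and on what is new or still open speak of the compounds shown alone.

Compound 1 `COc1cc2c(Oc3ccc(NC(=O)c4cc(-c5ccccc5C)ccn4)cc3F)ccnc2cc1OCCCN1CCCC1` and compound 2 `COc1cc2c(Oc3ccc(NC(=O)c4cc(-c5ccccc5F)ccn4)cc3F)ccnc2cc1OCCCN1CCCC1` share one core and differ in a single group: fluoro in place of methyl on an aromatic carbon. In a functional assay on HT-29 cells (Homo sapiens) for cytotoxicity, read by MTT assay, with a stated time of 72 h (on this read-out lower numbers stand for stronger inhibition and higher numbers for weaker inhibition), compound 1 gives 1150 nM, while compound 2 gives 230 nM, so that there is a 5.0-fold lower number from compound 1 to compound 2 (0.70 log units; beyond the scatter). Compound 3 `COc1cc2c(Oc3ccc(NC(=O)c4nccc(-c5ccc(C)cc5)n4)cc3F)ccnc2cc1OCCCN1CCCC1` is built on another core; the difference between the two cores is not broken down here. In this assay compound 3 gives 670 nM. Compound 4 `COc1cc2c(Oc3ccc(NC(=O)c4nccc(-c5ccc(F)cc5)n4)cc3F)ccnc2cc1OCCCN1CCCC1` has not been measured yet and differs from compound 3 by fluoro in place of methyl on an aromatic carbon. This is the same kind of change as between compound 1 and compound 2, but the place is not identical: in the first pair the carbon is ortho to a large group, in the second pair para to a large group, and the cores differ as well. A smaller step is expected this time, a 2.2-fold lower number from compound 3 to compound 4 (0.35 log units; beyond the scatter), because the earlier step of a 5.0-fold lower number from compound 1 to compound 2 (0.70 log units; beyond the scatter) came at another place and on another core. Compound 4 is therefore estimated at 300 nM, expected to fall between 120 nM and 800 nM.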

Compound 4, half-maximal inhibitory concentration: 160 nM
Estimate against measurement, compound 4: 1.9-fold (0.27 log units) above, within the range that was stated.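

In this assay, replacing methyl with fluoro again lowers the number, with a 4.2-fold lower number from compound 3 to compound 4 (0.62 log units; beyond the scatter). Set beside the earlier step, the change carries over from one core to the other at about the same size: the same change on two cores in this assay, a 5.0-fold lower number (0.70 log units; beyond the scatter) from compound 1 to compound 2 and a 4.2-fold lower number (0.62 log units; beyond the scatter) from compound 3 to compound 4, 1.2-fold (0.08 log units) apart, within the scatter of two such steps. Going by these compounds alone, this agreement rests on only two pairs, which differ in the place of the change as well as in the core, so it does not show that the step would hold on further cores, and it does not explain why the number falls.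

The compounds shown leave open how a chlorine, a methoxy group or an amine in that place would compare with fluoro. Going by these compounds, whether the steps would still match with the change at an identical place on both cores also stays open.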